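Hydroxy on the acetyl chain: cytotoxicity notes

A few compounds are considered here, and "the series" means these few. Any claim that something is new, unique, unknown or untested is made for them only; others in the source may bear on it.

Compound 2 `COc1ccc(C2=Cc3ccc(F)cc3C(CC(C)=O)N2c2ccc([N+](=O)[O-])cc2)cc1` gives 11200 nM in an ADME assay on TZM cells (Homo sapiens) for cytotoxicity, read by CellTiter-Glo, with a stated time of 48 h; a lower number here means that less compound is tolerated, a higher number that more compound is tolerated. Compound 3 `COc1ccc(C2=Cc3ccc([N+](=O)[O-])cc3C(CC(C)=O)N2c2ccc(C#N)cc2)cc1` gives 15400 nM in this assay, and the two numbers lie within the scatter of each other, so no order between them is claimed. For compound 1 `COc1ccc(C2=Cc3ccc(F)cc3C(CC(C)=O)N2c2ccc(F)cc2)cc1` the entry in this assay reads "not determined" (no result reported), so no result has been reported for it. Compound 4 `COc1ccc(C2=Cc3ccc(F)cc3C(CC(=O)CO)N2c2ccc([N+](=O)[O-])cc2)cc1` differs from compound 2 by hydroxy in place of hydrogen on a saturated chain carbon bound to a carbonyl carbon. Within the data shown here, no measured pair shows this change, so its effect in this assay is open; the step is expected to stay within the scatter, in no firm direction. Compound 4 is therefore estimated at 13000 nM, with a range of 6000 nM to 30000 nM. The expected step of a 1.2-fold higher number from compound 2 to compound 4 (0.06 log units; within the scatter) is thus small.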

Compound 4, half-maximal cytotoxic concentration: 46400 nM
Compound 4: the middle estimate sits 3.6-fold (0.55 log units) below what was measured; measured number above the stated range.
By their numbers in this assay, from the lowest: compounds 2 and 3 (each within the scatter of the next); then compound 4.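

In this assay, among these compounds, methyl to hydroxymethyl gives the first readable step, a 4.1-fold higher number from compound 2 to compound 4 (0.62 log units; beyond the scatter), and it lies beyond the scatter. This saturated chain carbon bound to a carbonyl carbon therefore tolerates a change that shifts the number upward, from a single matched pair. Nothing at hand explains the shift.

Going by these compounds, whether the same change holds on the core of compound 3 stays open. Also open, on these data alone, is whether an amine or a carboxylic acid in place of the hydroxy gives a step of similar size.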